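Limit Results and a Chlorophenyl Analogue in Liver Cells

The source may hold more compounds than are shown below. What is called first, only, known or untested is meant among the compounds shown, and "the series" means these compounds.

Compound 1 `C=C[C@@](C)(/C=C/c1ccc(O)c(/C=C/C(=O)c2ccccc2)c1)CCC=C(C)C` gives > 52000 nM as a limit.
Compound 2 `C=C[C@@](C)(/C=C/c1ccc(O)c(/C=C(\C)C(=O)OCC)c1)CCC=C(C)C` gives > 52000 nM as a limit.

In a functional assay on HepG2 cells (Homo sapiens) for cytotoxicity, with a stated time of 72 h (a lower number here means that less compound is needed, a higher number that more compound is needed for the effect), compound 2 stands at > 52000 nM and this is a limit, not a number. The only other result, for compound 1, is > 52000 nM and this too is a limit. Within the data shown here, no step between measured compounds can therefore be read from these data.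

Compound 3 `C=C[C@@](C)(/C=C/c1ccc(O)c(/C=C/c2ccc(Cl)cc2)c1)CCC=C(C)C` shares the core of compound 2 but carries 2-(4-chlorophenyl)ethenyl in place of 2-(ethoxycarbonyl)prop-1-en-1-yl on an aromatic carbon, ortho to a hydroxy group 2-(4-chlorophenyl)ethenyl in place of 2-(ethoxycarbonyl)prop-1-en-1-yl on an aromatic carbon with the rest unchanged.

In this assay no change beyond the usual scatter is expected, and no direction is favoured. That expectation rests on compound 1 and compound 2 sharing the limit of > 52000 nM in this assay, at which 2 of the 2 values shown sit, as their only result. The expected step that the limit leaves unreadable from compound 2 to compound 3 is thus a small one, and a further report as a limit is likely. The estimated value for compound 3 is 55000 nM with an expected range from 25000 nM to 120000 nM in this measurement.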

Compound 3, half-maximal effective concentration: > 52000 nM
Compound 3: only a limit was reported; the forecaster's own chance of this, stated with the estimate: 70%; the middle value does not contradict the limit.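

In this assay compound 3 gives > 52000 nM, which is a limit and not a number. No step from compound 1 or compound 2 to compound 3 can be read, because all three results are limits: the limit of > 52000 nM in this assay, at which 3 of the 3 values shown sit.

The compounds shown leave open whether 2-(4-chlorophenyl)ethenyl in place of 2-(ethoxycarbonyl)prop-1-en-1-yl changes the result at all.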